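A few compounds are considered here, and "the series" means these few. Any claim that something is new, unique, unknown or untested is made for them only; others in the source may bear on it.

Compound 2 `Cc1cc(NC(=O)c2c(F)cccc2F)nn1Cc1cc(Cl)ccc1OCc1ccccc1` gives 12.6 nM in an assay on CHO-K1 cells for displacement of a labelled ligand from prostaglandin E2 receptor EP1 subtype (Homo sapiens) (a higher number here means a weaker inhibitor, a lower number a stronger inhibitor), the lowest of the two numbers seen so far; compound 1 `Cc1cc(C(=O)Nc2cccc(F)c2)nn1Cc1cc(Cl)ccc1OCc1ccccc1` gives 200 nM in this assay. Among the compounds with values here, the only measured step, a 16-fold lower number from compound 1 to compound 2 (1.20 log units; beyond the scatter), shows that a change at the amide end of the shared core can move the number a great deal. Compound 3 `CCOC(=O)Nc1cc(C)n(Cc2cc(Cl)ccc2OCc2ccccc2)n1` carries another change at that same amide: ethoxy in place of 2,6-difluorophenyl on a carbonyl carbon. Within the data shown here, no measured step covers this particular swap, so its direction is uncertain, though a large shift is plausible. Compound 3 is expected to give 150 nM, within 30 nM to 800 nM. That estimate means a step of a 12-fold higher number from compound 2 to compound 3 (1.08 log units; beyond the scatter).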

Compound 3, half-maximal inhibitory concentration: 79.4 nM
Beside the measured number, compound 3's estimate is 1.9-fold (0.28 log units) above it; the measured number falls inside the stated range.
By their numbers in this assay, from the lowest: compound 2; then compound 3; then compound 1.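

At this carbonyl carbon an aromatic ring is not required for a fairly low number: swapping 2,6-difluorophenyl for the ring-free, smaller ethoxy gives a 6.3-fold higher number from compound 2 to compound 3 (0.80 log units; beyond the scatter), a real but limited loss. The (ethoxycarbonyl)amino group also still beats (3-fluorophenyl)carbamoyl, with a 2.5-fold lower number from compound 1 to compound 3 (0.40 log units; beyond the scatter). No available evidence explains either shift. Still open, as far as these compounds go, is whether a longer chain such as butoxy, or an amine such as dimethylamino, on that carbonyl carbon would lower or raise the number.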